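The source may hold more compounds than are shown below. What is called first, only, known or untested is meant among the compounds shown, and "the series" means these compounds.

Compound 3 `CCCSc1nc(N/N=C/c2cccs2)c2nnn(Cc3ccccc3)c2n1` stands at the edge of what a functional assay on MCF7 cells (Homo sapiens) for antiproliferative activity, read by MTT assay, with a stated time of 72 h (on this read-out higher numbers stand for weaker inhibition and lower numbers for stronger inhibition), can report: in this assay compound 3 gives > 64000 nM, which is a limit and not a number. Compound 1 `CCCSc1nc(N/N=C/c2cccnc2)c2nnn(Cc3ccccc3)c2n1` is the only one of the three measured compounds with a number, and in this assay compound 1 gives 58700 nM. Compound 2 `CCCSc1nc(N/N=C/c2cccc(Cl)c2)c2nnn(Cc3ccccc3)c2n1` is likewise at a limit; in this assay compound 2 gives > 64000 nM, a limit. The step from compound 1 to compound 2 is an at least 1.0-fold higher number from compound 1 to compound 2 (0.03 log units; that floor lies within the scatter), the step from compound 1 to compound 3 is an at least 1.0-fold higher number from compound 1 to compound 3 (0.03 log units; that floor lies within the scatter), and the step from compound 2 to compound 3 is a step that the two limits leave unreadable from compound 2 to compound 3. Two of the three values sit at the same limit (the limit of > 64000 nM in this assay, at which 2 of the 3 values shown sit).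

Compound 4 `CCCSc1nc(N/N=C/c2c(O)ccc3ccccc23)c2nnn(Cc3ccccc3)c2n1` differs from compound 3 in 2-hydroxynaphthalen-1-yl in place of thiophen-2-yl on a carbon with a double bond to nitrogen. Among the measured compounds shown here, none of the measured steps exchanges a group of this kind, and each of them is a floor within the scatter or unreadable, so they offer no direction. For compound 4 the step expected from compound 3 is an at least 1.2-fold lower number from compound 3 to compound 4 (0.10 log units; that floor lies within the scatter), that is, nothing beyond the scatter. Compound 4 is therefore expected to give 50000 nM in this assay, estimated between 12000 nM and 200000 nM.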

Compound 4, half-maximal inhibitory concentration: 6400 nM
Compound 4: middle estimate off by 7.8-fold (0.89 log units), on the high side; measured number outside the range, below it.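

In this assay, among the compounds shown here, exchange at this place, on a carbon with a double bond to nitrogen, moved the read-out beyond the scatter for the first time: 2-hydroxynaphthalen-1-yl brings an at least 10-fold lower number from compound 3 to compound 4 (1.00 log units; beyond the scatter), an at least 10-fold lower number from compound 2 to compound 4 (1.00 log units; beyond the scatter) and a 9.2-fold lower number from compound 1 to compound 4 (0.96 log units; beyond the scatter). The position is therefore not indifferent to its substituent, which pyridin-3-yl, 3-chlorophenyl and thiophen-2-yl alone could not show. Two of these steps are floors and not sizes, because compound 2 and compound 3 stand at a limit and not at a number: the limit of > 64000 nM in this assay, at which 2 of the 4 values shown sit.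

The entering group brings both its two six-membered aromatic rings and its hydroxy group, and the compounds shown do not separate the two. On these data alone, whether plain naphthalen-1-yl, 2-hydroxyphenyl or an amine in place of the hydroxy group would keep this gain stays open.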